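Working notes: chloro entry, compound 3 to compound 4

This account rests on a few compounds, and the source may have more. Where it says the series, first, only, none or still open, it means among the compounds named here.

Measured so far:
compound 1, `O=C(Nc1ccc(Sc2nc3ccccc3s2)cc1)c1ccccc1O` — a limit of the assay, > 100000 nM
compound 2, `O=C(Nc1ccc(Sc2nc3ccccc3s2)c(Cl)c1)c1cccc(Br)c1O` — 6900 nM
compound 3, `O=C(Nc1ccc(Sc2nc3ccccc3s2)cc1)c1ccccc1` — a limit of the assay, > 100000 nM

In an assay for inhibition of HSP60/HSP10 (Homo sapiens), with a stated time of 60 min (on this read-out higher numbers stand for weaker inhibition and lower numbers for stronger inhibition), compound 3 gives only a limit, > 100000 nM. Compound 1 likewise gives only a limit, > 100000 nM. Within the data shown here, the one measured single step, a step that the two limits leave unreadable from compound 1 to compound 3, cannot be read because both ends sit at the limit of > 100000 nM in this assay, at which 2 of the 3 values shown sit. Among the measured compounds shown here, compound 2, which carries the chloro together with bromo and hydroxy, gives 6900 nM; it is separated from compound 3 by more than one change, so no step between them is available, and its value shows only that a member of the series with the chloro present does register a number.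

Compound 4, `O=C(Nc1ccc(Sc2nc3ccccc3s2)c(Cl)c1)c1ccccc1`, differs from compound 3 by chloro in place of hydrogen on an aromatic carbon. For the measured compounds named here, no measured step bears directly on this change; the single step on record is unreadable. Compound 3 stands at the limit, so any number for compound 4 would already be a readable gain. Compound 4 is estimated at 60000 nM, within 15000 nM to 200000 nM, which means an expected step of an at least 1.6-fold lower number from compound 3 to compound 4 (0.22 log units; that floor lies within the scatter), with a fair chance that only a limit is reported again.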

Compound 4, half-maximal inhibitory concentration: > 100000 nM
Compound 4 was reported as a limit; the forecaster's own chance of this, stated with the estimate: 50%; middle value at least 1.6-fold (0.22 log units) from the limit.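

In this assay compound 4 gives > 100000 nM, which is a limit of the assay, so chloro in place of hydrogen at this position, ortho to a large group, does not on its own bring the unsubstituted benzamide into the readable range. Among these compounds, with the chloro kept, the change on the carbonyl carbon, phenyl in place of 3-bromo-2-hydroxyphenyl, gives the first readable step, an at least 14-fold higher number from compound 2 to compound 4 (1.16 log units; beyond the scatter), which ties the measurable value of compound 2 to that group rather than to the chloro alone. The steps with a limit at both ends cannot be read, and the comparison of the chloro change stops there: the limit of > 100000 nM in this assay, at which 3 of the 4 values shown sit.

What remains open is which part of the 3-bromo-2-hydroxyphenyl group carries the gain, and whether the chloro adds anything once that group is present, as the compounds shown do not separate the bromo, the hydroxy and the chloro from one another. Also open, going by these compounds, is how a methoxy or an amine in place of the hydroxy, or a fluoro or a methyl in place of the chloro, would read.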